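The source may hold more compounds than are shown below. What is called first, only, known or untested is meant among the compounds shown, and "the series" means these compounds.

Measured so far:
Compound 1, `N/C(=N\NC(=S)N1CCOCC1)c1ccccn1`: in a functional assay on HeLa cells (Homo sapiens) for cytotoxicity, read by MTT assay, with a stated time of 72 h, tested at 3 uM (on this read-out higher numbers stand for more inhibition of growth at the one concentration tested and lower numbers for less inhibition of growth), compound 1 gives 40%.
Compound 2, `Cc1cccc(/C(N)=N/NC(=S)N2CCSCC2)n1`: in this assay compound 2 gives 54.6%.

Compound 2 holds the higher of the two numbers in this assay; its nearest neighbour is compound 1, whose number lies lower by a gap that is beyond the scatter. For the measured compounds named here, compound 1 and compound 2 differ in more than one place, so their two values say only that much and give no single step to lean on.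

Compound 3, `Cc1cccc(/C(N)=N/NC(=S)N2CCOCC2)n1`, is not yet measured. It is reached from compound 2 by one change: morpholin-4-yl in place of thiomorpholin-4-yl on a thiocarbonyl carbon. Going by the values given here, no measured pair shows the same change on its own. Compound 1, which carries morpholin-4-yl, sits lower than compound 2 in this assay, but it also lacks the methyl group, so that difference cannot be read as the effect of the ring change alone.

For compound 3 a modest drop from compound 2 in this assay is expected, a step that may or may not clear the scatter, namely a number 8.6 percentage points lower from compound 2 to compound 3 (within the scatter). Compound 3 is estimated at 46%, with a range from 28% to 64%.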

Compound 3, percent growth inhibition at one concentration: 65.7%
Compound 3: the middle estimate sits 19.7 percentage points below what was measured; measured number outside the range, above it.
By their numbers in this assay, from the lowest: compound 1; then compound 2; then compound 3.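

In this assay the ring on the thiocarbonyl carbon now has a reading of its own: with the rest of the molecule held constant, morpholin-4-yl in place of thiomorpholin-4-yl gives a number 11.1 percentage points higher from compound 2 to compound 3 (beyond the scatter), so on this core the morpholin-4-yl compound shows the greater growth inhibition at the one concentration tested. Compound 3 also isolates the methyl group: with morpholin-4-yl kept in place, methyl in place of hydrogen on an aromatic carbon gives a number 25.7 percentage points higher from compound 1 to compound 3 (beyond the scatter), a single-change reading that the earlier pair, differing in two places, could not supply. No measurement at hand accounts for either step.

Going by these compounds, whether the ring step holds on the core without the methyl group stays open, since each of the two rings is compared on the methyl-bearing core only. Also open, on these data alone, is what a piperidin-1-yl or a piperazin-1-yl ring on the thiocarbonyl carbon would give, or an ethyl group or a methoxy group in place of the methyl on the aromatic carbon.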